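A few compounds are considered here, and "the series" means these few. Any claim that something is new, unique, unknown or untested is made for them only; others in the source may bear on it.

Measured compounds:
Compound 1, `Cc1cc(Nc2nccc(Nc3ccc4nc[nH]c4c3)n2)ccc1N1CCN(C)CC1`: 11 mL.min-1.g-1
Compound 2, `Cc1cccc(Nc2ncc([N+](=O)[O-])c(Nc3ccc4nc[nH]c4c3)n2)c1`: 26 mL.min-1.g-1

The study concerns two measured compounds and one that has not yet been tested. In an ADME assay on microsomes from liver (Mus musculus, strain CD1) for metabolic stability, read by HPLC, using NADPH, with a stated time of 30 min, tested at 0.5 uM (a lower number here means slower removal, a higher number faster removal of the compound), compound 1 gives 11 mL.min-1.g-1, the lower of the two numbers recorded. In this assay compound 2 gives 26 mL.min-1.g-1, a number that stands beyond the usual scatter above that of compound 1. Going by the values given here, no single-point step between the two measured compounds can be drawn, since they differ in more than one place, so the two values are simply taken as they stand.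

Compound 3, `CN1CCN(c2ccc(Nc3nccc(Nc4ccc5nc[nH]c5c4)n3)cc2)CC1`, has not yet been measured in this assay. It differs from compound 1 in one place: hydrogen in place of methyl on an aromatic carbon. The change is the loss of a single carbon on the aromatic ring that carries the 4-methylpiperazin-1-yl group, with the rest of the molecule, including the shared core, unchanged.

Among the compounds with values here, nothing among the measured pairs speaks to this particular change. A small step is expected, a 1.2-fold lower number from compound 1 to compound 3 (0.09 log units; within the scatter), lying within the scatter of repeated measurements rather than beyond it. Compound 3 is therefore estimated at 9 mL.min-1.g-1 in this assay, with a range from 4 mL.min-1.g-1 to 20 mL.min-1.g-1.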

Compound 3, intrinsic clearance in microsomes in the Mus musculus assay: 6 mL.min-1.g-1
Estimate against measurement, compound 3: 1.5-fold (0.18 log units) above; the range from low to high includes it.
By their numbers in the Mus musculus assay, from the lowest: compounds 3 and 1 (each within the scatter of the next); then compound 2.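

In the Mus musculus assay, the methyl on the aromatic carbon ortho to the 4-methylpiperazin-1-yl group can now be read directly, and exchanging it for hydrogen gives a 1.8-fold lower number from compound 1 to compound 3 (0.26 log units; within the scatter), so this position shows no difference that stands clear of repeated measurement. The same change does register elsewhere: in a physicochemical assay for lipophilicity, read by HPLC, using the shake flask method, measured as octanol-water partition, with a stated time of 6 h, at pH 7.4 (a lower number here means a more polar compound, a higher number a more lipophilic compound), compound 1 gives 2.9 and compound 3 gives 2.3. The step in the Mus musculus assay thus stays within the scatter even though the exchange of methyl for hydrogen leaves a less lipophilic compound as measured: the measured distribution coefficient of compound 1, 2.9, and of compound 3, 2.3, a number 0.60 log units lower (beyond the scatter)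

At this carbon only hydrogen and methyl are shown, so it remains open whether a halogen such as chlorine, or a larger group such as ethyl or methoxy, would also stay within the scatter in the Mus musculus assay. Which part of these molecules the microsomes act on is also left open, and compound 2 cannot help here, since it differs from compound 1 and compound 3 in more than one place.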